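A few compounds are considered here, and "the series" means these few. Any claim that something is new, unique, unknown or untested is made for them only; others in the source may bear on it.

Compound 3 `CCCCN1CCN(CCNC(=O)n2c(=O)n(C3CC3)c3ccccc32)CC1` sits second highest among the three measured compounds in an assay on isolated protein (striatum) for binding affinity to 5-hydroxytryptamine receptor 4 (Cavia porcellus), read by radioligand binding (on this read-out lower numbers stand for stronger inhibition and higher numbers for weaker inhibition), where compound 3 gives 13.3 nM. Compound 1 `CCCN1CCN(CCNC(=O)n2c(=O)n(C3CC3)c3ccccc32)CC1` stands nearest: in this assay compound 1 gives 8.2 nM, and the step of a 1.6-fold higher number from compound 1 to compound 3 (0.21 log units; within the scatter) lies within the scatter. Compound 2 `CCn1c(=O)n(C(=O)NCCN2CCN(C)CC2)c2ccccc21` stands furthest, and in this assay compound 2 gives 75.4 nM. Compound 4 `CCCCN1CCN(CCNC(=O)n2c(=O)n(CC)c3ccccc32)CC1` differs from compound 3 in a single place: ethyl in place of cyclopropyl on an aromatic nitrogen. Among the measured compounds shown here, no measured step covers this change; the only known step, methyl in place of hydrogen on a saturated chain carbon, alters a different part of the molecule and stays within the scatter. For the measured compounds named here, compound 2 does carry an ethyl on the aromatic nitrogen, but it differs from compound 3 in more than one place, so the two values show only that compound 2 is weaker than compound 3 in this assay. Compound 4 is therefore expected at 25 nM, with a range from 8 nM to 80 nM. The expected step of a 1.9-fold higher number from compound 3 to compound 4 (0.27 log units; within the scatter) points toward a weaker number, with wide uncertainty.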

Compound 4, inhibition constant: 34.1 nM
Compound 4: middle estimate off by 1.4-fold (0.13 log units), on the low side; low and high end bracket the measured number.
By their numbers in this assay, from the lowest: compounds 1 and 3 (each within the scatter of the next); then compound 4; then compound 2.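

In this assay, among the compounds shown here, the group on the aromatic nitrogen now has a measured effect on the number: ethyl in place of cyclopropyl gives a 2.6-fold higher number from compound 3 to compound 4 (0.41 log units; beyond the scatter) and thus shows that this position is not indifferent to the change, which the earlier compounds could not show. With ethyl held on that nitrogen, propyl in place of hydrogen on a saturated chain carbon bound to an amine nitrogen in a ring gives a 2.2-fold lower number from compound 2 to compound 4 (0.34 log units; beyond the scatter) and adds a modest step at the other end of the molecule. Nothing at hand explains the size of either step.

The compounds shown leave open how methyl, isopropyl or cyclobutyl on the aromatic nitrogen would compare with ethyl and cyclopropyl. They also leave open whether the ethyl and cyclopropyl step keeps its size when propyl replaces butyl on the amine nitrogen in a ring.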